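Swapping the aryl group on the shared core: an expectation

The compounds below may be only part of what the source reports. "The series", "measured", "known", "first", "only" and "open" are said of these compounds alone.

Measured compounds:
Compound 1, `C#CCN(CC=C)C(=O)[C@@]1(c2ccsc2)C[C@H]1CN`: > 10000 nM
Compound 2, `CCN(CC)C(=O)[C@@]1(c2cccnc2)C[C@H]1CN`: > 10000 nM
Compound 3, `CCN(CC)C(=O)[C@@]1(c2ccc(Cl)s2)C[C@H]1CN`: > 10000 nM

All three compounds were tested in an assay on HEK293 cells for inhibition of sodium-dependent dopamine transporter (Homo sapiens); a lower number here means a stronger inhibitor, a higher number a weaker inhibitor. For compound 1 the value is a limit of the assay, not a measured number. For compound 2 the value is likewise a limit. For compound 3 the value is a limit as well, so compound 3 stands at the edge of what this assay can report, together with the other two, as shown by the limit of > 10000 nM in this assay, at which 3 of the 3 values shown sit. Among the compounds with values here, the only single-point change among the measured compounds, a step that the two limits leave unreadable from compound 2 to compound 3, is therefore unreadable in size.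

Compound 4, `CCN(CC)C(=O)[C@@]1(c2ccccn2)C[C@H]1CN`, differs from compound 3 in one place: pyridin-2-yl in place of 5-chlorothiophen-2-yl on a saturated ring carbon. Within the data shown here, the one measured step that bears on this kind of change, the swap of an aryl group on the same ring carbon, gave no readable number, so no direction or size can be inferred for this assay beyond the scatter. Compound 4 is expected to sit near the limit too, with an estimated value of 15000 nM and a range from 5000 nM to 50000 nM. The step this estimate implies, a step that the limit leaves unreadable from compound 3 to compound 4, is expected to be unreadable in practice.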

Compound 4, half-maximal inhibitory concentration: > 10000 nM
Compound 4 ended at the assay's limit; the forecaster's own chance of this, stated with the estimate: 80%; the middle value does not contradict the limit.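

No new step can be read: the comparisons of compound 4 with compound 2 and with compound 3 give neither a size nor a direction, and all of these compounds share one assay limit: the limit of > 10000 nM in this assay, at which 4 of the 4 values shown sit. The compounds shown leave open whether any aryl group on the shared core gives a readable value in this assay, and how these aryl groups would rank.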